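Working notes: the step from compound 2 to compound 4

This account rests on a few compounds, and the source may have more. Where it says the series, first, only, none or still open, it means among the compounds named here.

Measured in a physicochemical assay for acid dissociation:
- compound 1 `CC(C)N1CCC(Oc2ccc3nc(C(=O)N4CCC4)ccc3c2)CC1`: 9.5
- compound 2 `COC1CCN(C(=O)c2ccc3cc(OC4CCN(C(C)C)CC4)ccc3c2)CC1`: 9.4
- compound 3 `CC1CCN(C(=O)c2ccc3cc(OC4CCN(C(C)C)CC4)ccc3c2)CC1`: 9.6

In this assay compound 2 gives 9.4, within the scatter of both compound 1 and compound 3. Compound 4 `COC1CCN(C(=O)c2ccc3cc(OCCCN4CCCCC4)ccc3c2)CC1` has not yet been measured. It differs from compound 2 as follows: 3-(piperidin-1-yl)propyl in place of 1-isopropylpiperidin-4-yl on an oxygen on an aromatic ring. That is, 3-(piperidin-1-yl)propyl stands in place of 1-isopropylpiperidin-4-yl on an oxygen on an aromatic ring.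

Among the compounds with values here, no measured compound carries the 3-(piperidin-1-yl)propyl group, so no measured step covers this change directly. Within the data shown here, the only step available, a number 0.20 log units higher from compound 2 to compound 3 (within the scatter), is methyl in place of methoxy on a saturated ring carbon, a change elsewhere in the structure. It bears only indirectly, as a sign of how little the values have moved so far. No shift beyond the scatter is expected, and the expected step is a number 0.10 log units higher from compound 2 to compound 4 (within the scatter). For compound 4 the estimated value is 9.5, with an expected range of 9.1 to 9.9.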

Compound 4, acid dissociation constant: 9.57
The estimate for compound 4 lay 0.07 log units below the measured number, and the stated range covers the measured number.
By their numbers in this assay, from the lowest: compounds 2, 1, 4 and 3 (each within the scatter of the next).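

In this assay the step on the oxygen on an aromatic ring, a number 0.17 log units higher from compound 2 to compound 4 (within the scatter), does not separate 3-(piperidin-1-yl)propyl from 1-isopropylpiperidin-4-yl. Within the data shown here, the only earlier step, methyl in place of methoxy on a saturated ring carbon, lay elsewhere in the structure, so this is the first reading at this position, and it shows that the same atoms joined differently in this group leave compound 2 and compound 4 indistinguishable here. No measurement shown offers an explanation for this result.

Still open, as far as these compounds go, is whether an ethyl or butyl chain in place of the propyl, or a morpholine or pyrrolidine in place of the piperidine, would stay within the scatter of compound 4 in this assay as well. Also open, from the compounds shown here alone, is whether 3-(piperidin-1-yl)propyl reads the same when paired with the methyl of compound 3.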